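Dropping the Chlorobenzoyl Group from Compound 2

The compounds below may be only part of what the source reports. "The series", "measured", "known", "first", "only" and "open" are said of these compounds alone.

Measured compounds:
compound 1: `CCC(=O)N1c2ccccc2CCC1C(=O)Nc1ccccc1C(F)(F)F`, > 80000 nM (a limit of the assay)
compound 2: `O=C(Nc1cc(C(F)(F)F)cc(C(F)(F)F)c1)C1CCc2ccccc2N1C(=O)c1ccc(Cl)cc1`, 1660 nM

Of the compounds shown here, two have been tested in a functional assay on NUGC-3 cells (Homo sapiens) for cytotoxicity, read by sulforhodamine B assay, with a stated time of 72 h; a higher number here means a weaker inhibitor of growth, a lower number a stronger inhibitor of growth. Compound 1 reaches only a limit of the assay, > 80000 nM. Among the compounds with values here, compound 2 gives 1660 nM, and this is the only actual number in hand; compound 2 therefore stands alone, with the other value being (the limit of > 80000 nM in this assay, at which 1 of the 2 values shown sits).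

Compound 3, `O=C(Nc1cc(C(F)(F)F)cc(C(F)(F)F)c1)C1CCc2ccccc2N1`, has not been measured. It differs from compound 2 in one place: hydrogen in place of (4-chlorophenyl)carbonyl on a nitrogen on an aromatic ring in a ring.

Within the data shown here, no step between measured compounds is known, so no direct precedent sets the size of this change. Since the (4-chlorophenyl)carbonyl group is a large part of compound 2, its removal is expected to weaken growth inhibition well beyond the scatter, from compound 2 to compound 3 by a 9.0-fold higher number from compound 2 to compound 3 (0.96 log units; beyond the scatter). Compound 3 is estimated at 15000 nM, within a range of 3000 nM to 80000 nM.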

Compound 3, concentration for 50% growth inhibition: 8760 nM
Beside the measured number, compound 3's estimate is 1.7-fold (0.23 log units) above it; measured number inside the range.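

In this assay, putting hydrogen in place of (4-chlorophenyl)carbonyl on a nitrogen on an aromatic ring in a ring gives a 5.3-fold higher number from compound 2 to compound 3 (0.72 log units; beyond the scatter), the first step read at this position. The change loses growth inhibition, but the group is not essential to it: compound 3, with only hydrogen on this nitrogen, still gives a real number of 8760 nM rather than a limit of the assay. Nothing in the data shown gives a reason for the size of this step.

This single step takes away the carbonyl and the 4-chlorophenyl ring together and cannot tell their shares apart; an acetyl group or a benzyl group on the same nitrogen would begin to separate them, and an unsubstituted benzoyl group would isolate the part played by the chlorine. From the compounds shown here alone, it also remains open whether the step keeps its size when the two trifluoromethyl groups of compound 2 and compound 3 are replaced, for example by methoxy groups.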